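Compound 3 and a longer piperazine-bearing chain

The source may report more compounds than this note shows. Statements on the series, on what has been measured and on what is new or still open speak of the compounds shown alone.

In a functional assay on SH-SY5Y cells (Homo sapiens) for cytotoxicity, read by MTT assay, with a stated time of 72 h (on this read-out higher numbers stand for weaker inhibition and lower numbers for stronger inhibition), compound 3 `O=C1c2c[n+]([O-])c3ccccc3c2C(=O)c2c1c1ccccc1n2CCN1CCCCC1` gives 1860 nM, the second highest of three numbers, with compound 1 `O=C1c2c[n+]([O-])c3ccccc3c2C(=O)c2c1c1ccccc1n2CCCCn1ccnc1` at 130 nM and compound 2 `CCCN1CCN(CCCCn2c3c(c4ccccc42)C(=O)c2c[n+]([O-])c4ccccc4c2C3=O)CC1` at 3970 nM. The next compound, compound 4 `CN1CCN(CCCCCCn2c3c(c4ccccc42)C(=O)c2c[n+]([O-])c4ccccc4c2C3=O)CC1`, has not yet been measured. Its change from compound 3 is 4-(4-methylpiperazin-1-yl)butyl in place of piperidin-1-yl on a saturated chain carbon, two bonds along the chain from an aromatic nitrogen, so that 4-(4-methylpiperazin-1-yl)butyl replaces piperidin-1-yl on a saturated chain carbon, two bonds along the chain from an aromatic nitrogen. The closest measured comparison is a 2.1-fold lower number from compound 2 to compound 3 (0.33 log units; beyond the scatter), a modest step that runs the opposite way, from a piperazine-bearing chain to piperidin-1-yl. The large steps of a 31-fold higher number from compound 1 to compound 2 (1.48 log units; beyond the scatter) and a 14-fold higher number from compound 1 to compound 3 (1.16 log units; beyond the scatter) both start from the 1H-imidazol-1-yl group of compound 1, which compound 4 lacks, so they bear on it less directly. A small rise in the number is therefore expected, no larger than that modest step. The expected change is a 1.5-fold higher number from compound 3 to compound 4 (0.18 log units; within the scatter). For compound 4 the estimated value is 2800 nM, with an expected range from 900 nM to 8000 nM.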

Compound 4, half-maximal inhibitory concentration: 920 nM
The estimate for compound 4 lay 3.0-fold (0.48 log units) above the measured number, and the stated range covers the measured number.
By their numbers in this assay, from the lowest: compound 1; then compound 4; then compound 3; then compound 2.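

In this assay, the larger 4-(4-methylpiperazin-1-yl)butyl group brought no loss against piperidin-1-yl at this saturated chain carbon, two bonds along the chain from an aromatic nitrogen: the step is a 2.0-fold lower number from compound 3 to compound 4 (0.31 log units; beyond the scatter) and runs opposite to the small rise expected. Two piperazine-bearing chains also proved clearly different, with a 4.3-fold lower number from compound 2 to compound 4 (0.64 log units; beyond the scatter), so a piperazine ring alone does not set the number here, although the 1H-imidazol-1-yl group keeps its lead, with a 7.1-fold higher number from compound 1 to compound 4 (0.85 log units; beyond the scatter). No evidence is available to explain these differences.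

Chain length and the alkyl group on the piperazine change together between the two piperazine-bearing compounds, so their separate contributions remain unresolved. Also open, as far as these compounds go, is how a morpholine ring or a primary amine would read at the end of such a chain.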